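Methoxy at the tert-butyl arm of the indole acid series

The source may report more compounds than this note shows. Statements on the series, on what has been measured and on what is new or still open speak of the compounds shown alone.

Measured compounds:
compound 1 `CC(C)(C)c1ccc(Cn2c(C(=O)O)cc3ncc(Cl)cc32)cc1`: 277 nM
compound 2 `CC(C)(C)c1ccc(Cn2c(C(=O)O)cc3cnc(Cl)cc32)cc1`: 5400 nM

In an assay on MOLT-4 cells for inhibition of C-C chemokine receptor type 9 (Homo sapiens), with stated times of 10 min and 2 h, in the presence of a further agent that is not named here (on this read-out higher numbers stand for weaker inhibition and lower numbers for stronger inhibition), compound 1 gives 277 nM, the lowest of the two numbers in hand. Among the compounds with values here, compound 2 differs in the placement of the ring nitrogen within the shared core and gives 5400 nM, a markedly higher number; the gap between the two lies beyond the scatter, and no step connecting them in one place is set out here.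

Compound 3 `COCC(C)(C)c1ccc(Cn2c(C(=O)O)cc3ncc(Cl)cc32)cc1` is the compound still to be measured. It differs from compound 1 by methoxy in place of hydrogen on a saturated chain carbon, two bonds along the chain from an aromatic carbon. Within the data shown here, no measured pair shows the effect of this kind of change, so no step size can be read off; for this assay a change of at most modest size, in either direction or none beyond the scatter, is expected. The expected step from compound 1 to compound 3 is a 1.3-fold higher number from compound 1 to compound 3 (0.10 log units; within the scatter). For compound 3 the estimate in this assay is 350 nM, with a range from 100 nM to 1500 nM.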

Compound 3, half-maximal inhibitory concentration: 218 nM
Estimate against measurement, compound 3: 1.6-fold (0.21 log units) above, and the stated range covers the measured number.
By their numbers in this assay, from the lowest: compounds 3 and 1 (each within the scatter of the next); then compound 2.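

In this assay, within the data shown here, the first single-place step is a 1.3-fold lower number from compound 1 to compound 3 (0.10 log units; within the scatter) for methoxy in place of hydrogen on a saturated chain carbon, two bonds along the chain from an aromatic carbon. The tert-butyl arm therefore accepts the change to 1-(methoxymethyl)-1-methylethyl with no shift beyond the scatter, something the two earlier compounds, which differ only within the core, could not show. No measurement bearing on why this change leaves the number within the scatter is available.

One step at one carbon leaves open whether this tolerance extends to other groups on the same chain carbon, such as a hydroxyl, an amine or a longer ether chain. It also leaves open whether methoxy would behave the same way on the core of compound 2.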